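Two Benzoyl Variants and a Chloro-Fluoro Successor

This account rests on a few compounds, and the source may have more. Where it says the series, first, only, none or still open, it means among the compounds named here.

Compound 1 `CN1CCN(c2ccc(Nc3nc(-c4cccc(NC(=O)c5ccccc5)c4)sc3C(N)=O)cc2)CC1` gives 1760 nM in a functional assay on Ramos cells (Homo sapiens) for antiproliferative activity, read by CCK-8 assay, with a stated time of 72 h; a higher number here means a weaker inhibitor, a lower number a stronger inhibitor.
Compound 2 `CN1CCN(c2ccc(Nc3nc(-c4cccc(NC(=O)c5ccccc5F)c4)sc3C(N)=O)cc2)CC1` gives 1360 nM in this assay.

Going by the values given here, the only step between measured compounds, a 1.3-fold lower number from compound 1 to compound 2 (0.11 log units; within the scatter), lies within the scatter. Compound 2 therefore stands alongside compound 1, the two numbers being within the scatter of each other, so neither can be called the stronger.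

Compound 3 `CN1CCN(c2ccc(Nc3nc(-c4cccc(NC(=O)c5ccc(F)c(Cl)c5)c4)sc3C(N)=O)cc2)CC1` has not yet been measured. It differs from compound 2 by 3-chloro-4-fluorophenyl in place of 2-fluorophenyl on a carbonyl carbon. Among the compounds with values here, no measured step bears on the entering 3-chloro-4-fluorophenyl group; the one step at hand, a 1.3-fold lower number from compound 1 to compound 2 (0.11 log units; within the scatter), concerned a single fluorine and was within the scatter. Compound 3 is therefore expected to give a number close to that of compound 2, a step of a 1.1-fold lower number from compound 2 to compound 3 (0.05 log units; within the scatter), with no shift beyond the scatter. The estimate for compound 3 is 1200 nM, with a range from 500 nM to 3000 nM.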

Compound 3, half-maximal inhibitory concentration: 4830 nM
The estimate for compound 3 lay 4.0-fold (0.60 log units) below the measured number; the whole stated range lies below it.
By their numbers in this assay, from the lowest: compounds 2 and 1 (each within the scatter of the next); then compound 3.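

Going by these compounds alone, at this position, the carbonyl carbon of the amide, this assay gives the first readable response to a change of the aromatic group: the single fluorine of compound 2 stayed within the scatter of compound 1, whereas the 3-chloro-4-fluorophenyl group gives a 3.6-fold higher number from compound 2 to compound 3 (0.55 log units; beyond the scatter) and a 2.7-fold higher number from compound 1 to compound 3 (0.44 log units; beyond the scatter). Within the data shown here, both steps are modest and both point towards a weaker inhibitor, so this position does respond to its substituents, and among the three compounds the only change beyond the scatter is a loss. Nothing measured here accounts for this rise.

Compound 3 differs from compound 2 in both the chlorine and the placing of the fluorine, so the compounds shown do not separate these two changes. On these data alone, how a methoxy group or an amine on this phenyl ring would fare also remains open.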